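This account rests on a few compounds, and the source may have more. Where it says the series, first, only, none or still open, it means among the compounds named here.

Of the compounds shown here, two have been measured in a functional assay on M14 cells (Homo sapiens) for inhibition, read by sulforhodamine B assay, with a stated time of 48 h, tested at 10 uM; on this read-out lower numbers stand for a stronger effect and higher numbers for a weaker effect at the one concentration tested. Going by the values given here, compound 1 `COc1cc(Cl)cc(-c2nn(-c3cccc(NC(=O)c4ccc(Cl)c(Cl)c4)c3)cc2-c2ccncc2)c1` gives 68.9%, while compound 2 `COc1cc(Cl)cc(-c2nn(-c3cccc(NC(=O)Nc4ccc(Cl)c(Cl)c4)c3)cc2-c2ccncc2)c1` gives 18.7%, so compound 2 stands lowest of the two numbers, with compound 1 as its only neighbour. The step of a number 50.2 percentage points lower from compound 1 to compound 2 (beyond the scatter) links them: (3,4-dichlorophenyl)amino in place of 3,4-dichlorophenyl on a carbonyl carbon. Compound 3 `COc1cc(Cl)cc(-c2nn(-c3cccc(NC(=O)c4cccc(C(F)(F)F)c4)c3)cc2-c2ccncc2)c1` is not yet measured. It differs from compound 2 by 3-(trifluoromethyl)phenyl in place of (3,4-dichlorophenyl)amino on a carbonyl carbon, on a carbonyl carbon whose other neighbour is an amide-type nitrogen. Among the compounds with values here, this change partly reverses the measured step, since the (3,4-dichlorophenyl)amino group leaves again, but no measured pair covers the 3-(trifluoromethyl)phenyl group, so the aryl part of the change is unsupported. A step of a number 41.3 percentage points higher from compound 2 to compound 3 (beyond the scatter) is therefore expected, upward, beyond the scatter. Compound 3 is estimated to give 60%, within 35% to 88% in this assay.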

Compound 3, a percentage reported as activity, at one concentration (the size of the read-out at that concentration, not a potency): 56.3%
For compound 3 the middle estimate is 3.7 percentage points above the measured one; the measured number falls inside the stated range.
By their numbers in this assay, from the lowest: compound 2; then compound 3; then compound 1.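

In this assay, the low number of compound 2 does not carry over once its (3,4-dichlorophenyl)amino group gives way to another aryl group on the carbonyl carbon, as the large step of a number 37.6 percentage points higher from compound 2 to compound 3 (beyond the scatter) shows. The aryl group set directly on that carbonyl carbon also counts, though by less, with a modest step of a number 12.6 percentage points lower from compound 1 to compound 3 (beyond the scatter) for 3-(trifluoromethyl)phenyl in place of 3,4-dichlorophenyl. Nothing at hand explains either step.

Still open, as far as these compounds go, is whether a (3-(trifluoromethyl)phenyl)amino group on the same carbonyl carbon would give a number as low as that of compound 2, which would separate the effect of the amino link from that of the ring substituents. Also open, from the compounds shown here alone, is how a benzylamino group, with its longer link to the ring, would behave at this position.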